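The compounds below may be only part of what the source reports. "The series", "measured", "known", "first", "only" and "open" are said of these compounds alone.

Series notes. Compound 1 `CC(=O)/C(=N\c1ccccc1)NNc1ccccc1C` gives 526 nM in an assay on isolated protein for binding affinity to corticotropin-releasing factor receptor 1 (Homo sapiens); on this read-out higher numbers stand for weaker inhibition and lower numbers for stronger inhibition. Compound 2 `CC(=O)/C(=N\c1cccc(C)c1)NNc1ccccc1C` gives 526 nM in this assay, and no change at the digits printed from compound 1 to compound 2 (within the scatter). Compound 3 `C#Cc1cccc(/N=C(/NNc2ccccc2C)C(C)=O)c1` gives 62 nM in this assay, the lowest of the three numbers; its nearest neighbour, compound 1, lies beyond the scatter, as does compound 2. Compound 4 `CC(=O)/C(=N\c1cccc(C(F)(F)F)c1)NNc1ccccc1C` is not yet measured; it differs from compound 3 by trifluoromethyl in place of ethynyl on an aromatic carbon. Going by the values given here, two measured steps bear on this change: an 8.5-fold lower number from compound 2 to compound 3 (0.93 log units; beyond the scatter) and an 8.5-fold lower number from compound 1 to compound 3 (0.93 log units; beyond the scatter). Both show that ethynyl on that aromatic carbon goes with a modest lowering of the number, whereas methyl and hydrogen there give the same number within the scatter. Nothing measured in the set shows how trifluoromethyl on that aromatic carbon behaves; the step from compound 3 to compound 4 removes the ethynyl and puts in a group without precedent here. The expectation is therefore a move back toward the numbers of compound 1 and compound 2, with an expected 4.0-fold higher number from compound 3 to compound 4 (0.61 log units; beyond the scatter). For compound 4 the estimate in this assay is 250 nM, with an expected range from 80 nM to 800 nM.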

Compound 4, inhibition constant: 291 nM
For compound 4 the middle estimate is 1.2-fold (0.07 log units) below the measured one, and the stated range covers the measured number.
By their numbers in this assay, from the lowest: compound 3; then compounds 4, 1 and 2 (each within the scatter of the next).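

Placing trifluoromethyl on this aromatic carbon does not retain the result seen with ethynyl in this assay, with a 4.7-fold higher number from compound 3 to compound 4 (0.67 log units; beyond the scatter). Trifluoromethyl instead groups with methyl and hydrogen at this place, with a 1.8-fold lower number from compound 2 to compound 4 (0.26 log units; within the scatter) and a 1.8-fold lower number from compound 1 to compound 4 (0.26 log units; within the scatter), so ethynyl is the only one of the four groups shown that stands apart from the others. No supporting information bears on why ethynyl differs from the other three groups.

Open, going by these compounds, is whether the lower number is particular to ethynyl or also appears with other groups containing a triple bond, such as a nitrile or a propynyl chain. Also open, on these data alone, is how a chlorine atom or a methoxy group would behave on this aromatic carbon.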